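This account rests on a few compounds, and the source may have more. Where it says the series, first, only, none or still open, it means among the compounds named here.

In an ADME assay on HCT-116 cells (Homo sapiens) for cytotoxicity, read by CellTiter-Glo, with a stated time of 72 h (a higher number here means a weaker inhibitor, a lower number a stronger inhibitor), compound 1, `Cc1cc(C)c(S(=O)(=O)N2CCC(c3ccccc3)CC2)c(C)c1`, gives only a limit of the assay, > 5000 nM. Compound 2, `Cc1cc(C)c(S(=O)(=O)N2CCC(N3CCC(Cc4ccc(F)cc4)CC3)CC2)c(C)c1`, likewise returns only a limit in this assay, > 5000 nM. For the measured compounds named here, compound 2 therefore stands at the limit of > 5000 nM in this assay, at which 2 of the 2 values shown sit, and since neither of the two values shown is a number, no step between the measured compounds can be drawn; the two values show only that both compounds sit at the same limit. Compound 3, `Cc1cc(C)c(S(=O)(=O)N2CCC(N3CCC(O)CC3)CC2)c(C)c1`, has not yet been measured in this assay. It differs from compound 2 in a single place: hydroxy in place of 4-fluorobenzyl on a saturated ring carbon. The change sits on a saturated ring carbon of a six-membered non-aromatic ring with 1 nitrogen, three ring bonds from the ring nitrogen. With no measured step available and both shown values at the limit, the step from compound 2 to compound 3 in this assay is expected to be none beyond the usual scatter, most likely ending again at a limit. Compound 3 is accordingly expected to give about 8000 nM, within a range from 4000 nM to 20000 nM. That estimate means a step that the limit leaves unreadable from compound 2 to compound 3, expected to lie within the scatter.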

Compound 3, half-maximal inhibitory concentration: > 5000 nM
Compound 3: only a limit was reported; the forecaster's own chance of this, stated with the estimate: 80%; the middle value is on the limit's open side.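

Compound 3 gives only a limit of the assay in this assay, > 5000 nM, so no step can be read from compound 1 or compound 2 to compound 3. The compounds shown leave open whether hydroxy and 4-fluorobenzyl on that saturated ring carbon differ at all in this assay, as none has yielded a number.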